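The source may hold more compounds than are shown below. What is called first, only, known or untested is meant among the compounds shown, and "the series" means these compounds.

Measured in an in vitro ADME assay on microsomes from liver (Homo sapiens) for metabolic stability; a higher number here means faster removal of the compound, a lower number slower removal:
Compound 1 `CN1CC(=O)N/C1=N\C(=O)Nc1ccncc1`: 11 mL.min-1.g-1
Compound 2 `CN1CC(=O)N/C1=N\C(=O)Nc1cccnc1`: 20 mL.min-1.g-1

The values of these two compounds lie within the usual scatter of each other, and compound 1 therefore stands level with compound 2. Compound 3 `Cc1cnccc1NC(=O)/N=C1\NC(=O)CN1C` is compound 1 with methyl in place of hydrogen on an aromatic carbon. Among the measured compounds shown here, no measured pair shows this kind of change, which leaves the expectation in this assay uncertain. The expected change is small and upward, a 1.4-fold higher number from compound 1 to compound 3 (0.13 log units; within the scatter), and would not go beyond the scatter. The estimate for compound 3 is 15 mL.min-1.g-1, with an expected range of 7 mL.min-1.g-1 to 32 mL.min-1.g-1.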

Compound 3, intrinsic clearance in microsomes: 2 mL.min-1.g-1
Estimate against measurement, compound 3: 7.5-fold (0.88 log units) above; the whole stated range lies above it.
By their numbers in this assay, from the lowest: compound 3; then compounds 1 and 2 (each within the scatter of the next).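

In this assay the methyl in place of hydrogen on an aromatic carbon, ortho to a large group and two atoms from the ring nitrogen, gives a clear shift: a 5.5-fold lower number from compound 1 to compound 3 (0.74 log units; beyond the scatter). This shows that one added methyl at this position can move the read-out beyond the scatter, which the two earlier compounds could not show. Nothing shown here gives a cause for this shift.

On these data alone, it remains open whether ethyl, methoxy or fluorine on the same carbon would move the number as far. As far as these compounds go, it is also open whether methyl on the ring of compound 2 would give a similar step.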